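Swapping chloro for hydroxy in compound 2

The compounds below may be only part of what the source reports. "The series", "measured", "known", "first", "only" and "open" are said of these compounds alone.

compound 1 `Nc1nc(Cl)c2ncn([C@H]3CCC[C@H]3CO)c2n1`: 83000 nM
compound 2 `Nc1nc(Cl)c2nnn([C@H]3CCC[C@H]3CO)c2n1`: 53000 nM
compound 3 `Nc1nc(O)c2ncn([C@H]3CCC[C@H]3CO)c2n1`: a limit of the assay, > 200000 nM

Of the compounds shown here, three sharing one core have been measured in a functional assay on CCRF-CEM cells (Homo sapiens) for antiproliferative activity; a higher number here means a weaker inhibitor, a lower number a stronger inhibitor. Compound 2 and compound 1 return numbers that sit within the usual scatter of each other, so no order between them can be read. Compound 3 reaches only the limit of the assay. The next compound, compound 4 `Nc1nc(O)c2nnn([C@H]3CCC[C@H]3CO)c2n1`, takes compound 2 and makes one change: hydroxy in place of chloro on an aromatic carbon.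

For the measured compounds named here, one measured step bears directly on this change. On the core of compound 1, the same swap gave an at least 2.4-fold higher number from compound 1 to compound 3 (0.38 log units; beyond the scatter), and the true size of that step is hidden because compound 3 sits at the limit of > 200000 nM in this assay, at which 1 of the 3 values shown sits. The step from compound 2 to compound 4 is therefore expected to run in the same direction, weakening, and to be at least modest, with a real chance that compound 4 also lands on the limit of this assay rather than on a number.

On that basis compound 4 is estimated at 200000 nM, within a range of 100000 nM to 600000 nM. This estimate for compound 4 corresponds to an expected step of a 3.8-fold higher number from compound 2 to compound 4 (0.58 log units; beyond the scatter).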

Compound 4, half-maximal inhibitory concentration: 86700 nM
The estimate for compound 4 lay 2.3-fold (0.36 log units) above the measured number; measured number below the stated range.
By their numbers in this assay, from the lowest: compounds 2, 1 and 4 (each within the scatter of the next). At a limit, above all of these: compound 3.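

In this assay, hydroxy in place of chloro on this aromatic carbon, next to the ring nitrogen, now gives a measured number on both sides of the step, with a 1.6-fold higher number from compound 2 to compound 4 (0.21 log units; within the scatter). On the core of compound 2, then, the swap produces no change that can be told from the scatter, and the weakening seen on the core of compound 1 does not hold as a clear rule for this position, with compound 4 as the case that goes against it. Whether the two cores truly respond differently cannot be settled, however, as the comparison rests on one step that ends at a limit of the assay: the same change on two cores in this assay, an at least 2.4-fold higher number (0.38 log units; beyond the scatter) from compound 1 to compound 3 and a 1.6-fold higher number (0.21 log units; within the scatter) from compound 2 to compound 4; the limit leaves it open whether they differ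

The compounds shown leave open whether an amine or a methoxy group on this same carbon would give a number in this assay beyond the scatter of those for chloro and hydroxy. They also leave open whether a longer chain on the hydroxymethyl side of the cyclopentane-bearing part, or an amine there, would shift these numbers at all.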